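Swapping Chlorine for Fluorine on Compound 1

The compounds below may be only part of what the source reports. "The series", "measured", "known", "first", "only" and "open" are said of these compounds alone.

Compound 1 `Cc1cn(C2CCN(Cc3cccc(Oc4cc(Cl)cc(Cl)c4)c3)CC2)c(=O)[nH]c1=O`: 6730 nM
Compound 2 `Cc1cn(C2CCN(Cc3cc(Oc4cccc(Cl)c4)ccn3)CC2)c(=O)[nH]c1=O`: > 64000 nM
Compound 3 `Cc1cn(C2CCN(Cc3cccc(Oc4cccc(Cl)c4)n3)CC2)c(=O)[nH]c1=O`: > 64000 nM

Among the compounds with values here, in an ADME assay on MRC5 cells (Homo sapiens) for cytotoxicity, read by fluorescence and resazurin assay, with a stated time of 3 days (a lower number here means a stronger inhibitor, a higher number a weaker inhibitor), compound 1 gives 6730 nM, the only exact number in this small set. Compound 2 reads > 64000 nM, which is a limit and not a number. Compound 3 reads > 64000 nM, which is also a limit. The picture is therefore one number and a ceiling: the limit of > 64000 nM in this assay, at which 2 of the 3 values shown sit.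

Compound 4 `Cc1cn(C2CCN(Cc3cccc(Oc4cc(F)cc(F)c4)c3)CC2)c(=O)[nH]c1=O` has not been measured yet. It keeps the core of compound 1 and changes one group, with 3,5-difluorophenyl in place of 3,5-dichlorophenyl on an oxygen on an aromatic ring.

Within the data shown here, no measured pair here shows a change of this kind, so the size of the step is a judgement. In this assay a moderate step beyond the scatter is expected, toward a higher number and so weaker cytotoxicity. The estimated change is a 3.3-fold higher number from compound 1 to compound 4 (0.51 log units; beyond the scatter). For compound 4 the expected value is 22000 nM, with an estimated range from 9000 nM to 64000 nM.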

Compound 4, half-maximal inhibitory concentration: > 64000 nM
Compound 4 ended at the assay's limit; the forecaster's own chance of this, stated with the estimate: 20%; at least 2.9-fold (0.46 log units) between middle value and limit.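

In this assay compound 4 reads > 64000 nM, which is a limit of the assay and not a number. Within the data shown here, replacing 3,5-dichlorophenyl with 3,5-difluorophenyl on an oxygen on an aromatic ring gives an at least 9.5-fold higher number from compound 1 to compound 4 (0.97 log units; beyond the scatter), the only step in this set that can be read, and it shows that this single change moves the value beyond the scatter while the rest of compound 1 stays the same. Because compound 4 stops at the ceiling, only the smallest possible size of this step is known: the limit of > 64000 nM in this assay, at which 3 of the 4 values shown sit.

On these data alone, how far the true value of compound 4 lies past the limit remains unknown. As far as these compounds go, it also remains open whether an unsubstituted phenyl or a phenyl carrying an amine in this place would reach the same limit.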